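The source may report more compounds than this note shows. Statements on the series, on what has been measured and on what is new or still open speak of the compounds shown alone.

Of the compounds shown here, three have been measured in an assay on isolated protein for inhibition of Leucine-rich repeat serine/threonine-protein kinase 2 variant G2019S (Homo sapiens), read by TR-FRET and LanthaScreen, with stated times of 50 min and 30 min, in the presence of a further agent that is not named here; a higher number here means a weaker inhibitor, a lower number a stronger inhibitor. Compound 1 `Cc1nn(C2COC2)cc1Nc1nc(N)c2c(C#N)c(N3CCC[C@H]3C)n(C)c2n1` gives 25 nM, and compound 2 `Cc1c(Nc2nc(N)c3c(C#N)c(N4CCC[C@H]4C)n(C)c3n2)cnn1C1COC1` gives 37 nM; the step of a 1.5-fold higher number from compound 1 to compound 2 (0.17 log units; within the scatter) separates them. Compound 3 `C[C@@H]1CCCN1c1c(C#N)c2c(N)nc(N)nc2n1C`, which carries only a hydrogen where the other two carry a substituted pyrazolyl group, gives 217 nM and so has the highest number of the three, that is, the weakest inhibition.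

Compound 4 `Cc1n[nH]cc1Nc1nc(N)c2c(C#N)c(N3CCC[C@H]3C)n(C)c2n1` is not yet measured. Its difference from compound 3 is 3-methyl-1H-pyrazol-4-yl in place of hydrogen on a nitrogen on an aromatic ring. The group that enters is the pyrazolyl part of the substituents in compounds 1 and 2, but without the oxetanyl ring attached to it.

For the measured compounds named here, the steps that bear on this change run in the opposite direction: an 8.7-fold higher number from compound 1 to compound 3 (0.94 log units; beyond the scatter) and a 5.9-fold higher number from compound 2 to compound 3 (0.77 log units; beyond the scatter). Both show that removing the pyrazolyl substituent weakens inhibition to a modest degree. Restoring a pyrazolyl group, even without the oxetanyl ring, is therefore expected to lower the number again, by roughly the same modest size, giving the expected step of a 4.8-fold lower number from compound 3 to compound 4 (0.68 log units; beyond the scatter). Compound 4 is expected to give about 45 nM in this assay, within a range from 15 nM to 130 nM.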

Compound 4, half-maximal inhibitory concentration: 27 nM
Beside the measured number, compound 4's estimate is 1.7-fold (0.22 log units) above it; low and high end bracket the measured number.
By their numbers in this assay, from the lowest: compounds 1, 4 and 2 (each within the scatter of the next); then compound 3.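

In this assay, the 3-methyl-1H-pyrazol-4-yl group alone, with no oxetanyl ring, is enough to bring the number down from that of the amino compound (an 8.0-fold lower number from compound 3 to compound 4 (0.91 log units; beyond the scatter)). Replacing oxetan-3-yl with hydrogen on the aromatic nitrogen leaves the number within the scatter (a 1.1-fold higher number from compound 1 to compound 4 (0.03 log units; within the scatter)), and the same holds against the 5-methyl isomer (a 1.4-fold lower number from compound 2 to compound 4 (0.14 log units; within the scatter)), so the oxetan-3-yl group is not required for inhibition in these compounds. No measured evidence shows why the pyrazolyl group has this effect.

These compounds leave open whether a group other than oxetan-3-yl on that ring nitrogen, such as a methyl group or a longer chain ending in an amine, would also leave the number unchanged. They also leave open whether the ring methyl matters, since every pyrazolyl compound here carries one.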